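Difluorophenyl Replaces Methoxyphenyl on the Carbonyl Carbon

A few compounds are considered here, and "the series" means these few. Any claim that something is new, unique, unknown or untested is made for them only; others in the source may bear on it.

Compound 1 `COc1cc(-c2cc(/C=C/C(=O)c3ccc(N)cc3)[nH]n2)cc(OC)c1OC` gives 2990 nM in a functional assay on SK-OV-3 cells (Homo sapiens) for inhibition, read by sulforhodamine B assay, with a stated time of 48 h; a higher number here means a weaker inhibitor of growth, a lower number a stronger inhibitor of growth.
Compound 2 `COc1ccc(C(=O)/C=C/c2cc(-c3cc(OC)c(OC)c(OC)c3)n[nH]2)cc1OC` gives 2790 nM in this assay.
Compound 3 `COc1ccc(C(=O)/C=C/c2cc(-c3cc(OC)c(OC)c(OC)c3)n[nH]2)cc1` gives 3990 nM in this assay.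

The number of compound 3 is the highest of the three, but the steps of a 1.3-fold higher number from compound 1 to compound 3 (0.13 log units; within the scatter) and a 1.4-fold higher number from compound 2 to compound 3 (0.16 log units; within the scatter) both lie within the scatter, so the three compounds cannot be ordered. Compound 4 `COc1cc(-c2cc(/C=C/C(=O)c3ccc(F)c(F)c3)[nH]n2)cc(OC)c1OC` differs from compound 3 by 3,4-difluorophenyl in place of 4-methoxyphenyl on a carbonyl carbon. The measured steps that bear on this change all alter the aryl group on the carbonyl carbon: a 1.1-fold lower number from compound 1 to compound 2 (0.03 log units; within the scatter), a 1.3-fold higher number from compound 1 to compound 3 (0.13 log units; within the scatter) and a 1.4-fold higher number from compound 2 to compound 3 (0.16 log units; within the scatter), each within the scatter. No step beyond the scatter is therefore expected in this assay, and the expected step is a 1.1-fold lower number from compound 3 to compound 4 (0.06 log units; within the scatter). Compound 4 is estimated at 3500 nM, with a range from 1500 nM to 9000 nM.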

Compound 4, concentration for 50% growth inhibition: 3530 nM
Compound 4: middle estimate off by 1.0-fold (0.00 log units), on the low side; the measured number falls inside the stated range.
By their numbers in this assay, from the lowest: compounds 2, 1, 4 and 3 (each within the scatter of the next).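

In this assay, 3,4-difluorophenyl on the carbonyl carbon stays within the scatter of all three earlier aryl groups: 4-methoxyphenyl (a 1.1-fold lower number from compound 3 to compound 4 (0.05 log units; within the scatter)), 3,4-dimethoxyphenyl (a 1.3-fold higher number from compound 2 to compound 4 (0.10 log units; within the scatter)) and 4-aminophenyl (a 1.2-fold higher number from compound 1 to compound 4 (0.07 log units; within the scatter)). Replacing oxygen with fluorine here, and going from 1 hydrogen-bond acceptor to 0 in the group, thus leaves the number within the scatter. No measurement offered here explains this result.

Still open, from the compounds shown here alone, is whether any group at this position moves the number beyond the scatter, for example an aryl group carrying a carboxylic acid, or a longer chain in place of the aryl group.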